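The source may report more compounds than this note shows. Statements on the series, on what has been measured and on what is new or still open speak of the compounds shown alone.

Compound 1 `Cc1c(C)c2c(c(C)c1OC(=O)CCCCCCCNC(=O)OC(C)(C)C)CCC(C)(COc1ccc(/C=C3\SC(=O)NC3=O)cc1)O2`: 74.7%
Compound 2 `Cc1c(C)c2c(c(C)c1OC(=O)OC(C)(C)C)CCC(C)(CN1C(=O)S/C(=C\c3ccc(O)cc3)C1=O)O2`: 37.8%

In an ADME assay on cells (Hepatocyte, Homo sapiens) for cytotoxicity, read by MTT assay, with a stated time of 90 min, tested at 200 uM (a lower number here means a stronger effect, a higher number a weaker effect of the compound at the concentration tested), compound 2 gives the lower of these two numbers, and compound 1 stands well beyond the scatter above it. Compound 3 `Cc1c(C)c2c(c(C)c1O)CCC(C)(CN1C(=O)S/C(=C\c3ccc(O)cc3)C1=O)O2` differs from compound 2 in one place: hydrogen in place of tert-butoxycarbonyl on an oxygen on an aromatic ring. For the measured compounds named here, no measured pair shows this change, so its effect can only be guessed; in this assay I expect a modest move toward a higher number, one that may not clearly clear the scatter. For compound 3 the estimate is 50%, with a range from 25% to 80%. That estimate means an expected step of a number 12.2 percentage points higher from compound 2 to compound 3 (beyond the scatter).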

Compound 3, a percentage reported as activity, at one concentration (the size of the read-out at that concentration, not a potency): 103%
For compound 3 the middle estimate is 53 percentage points below the measured one; the measured number lies above the stated range.
By their numbers in this assay, from the lowest: compound 2; then compound 1; then compound 3.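

For the compounds shown here, replacing tert-butoxycarbonyl with hydrogen on an oxygen on an aromatic ring gives a number 65.2 percentage points higher from compound 2 to compound 3 (beyond the scatter) in this assay and is the first single-place comparison here. It shows that this one group can strongly change the read-out, with the free hydroxy giving the higher number, which means the weaker effect at the concentration tested. Nothing available explains the size of this step. Still open, from the compounds shown here alone, is whether a smaller group on this oxygen, such as acetyl or methyl, would give a number nearer compound 2 or compound 3. A single pair also cannot show whether this step would recur on another core.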